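The source may report more compounds than this note shows. Statements on the series, on what has been measured and on what is new or still open speak of the compounds shown alone.

Measured compounds: compound 1 `CC/C(=C(/c1ccc(/C=C/C(=O)O)cc1)c1cc2ccccc2[nH]1)c1ccccc1Cl` with 42 nM; compound 2 `CC/C(=C(/c1ccc(/C=C/C(=O)O)cc1)c1cc2ccccc2[nH]1)c1ccccc1C#N` with 9 nM; compound 3 `CC/C(=C(/c1ccc(/C=C/C(=O)O)cc1)c1cc2ccccc2[nH]1)c1ccc(Cl)cc1Cl` with 11 nM, all in a functional assay on MCF7 cells (Homo sapiens) for inhibition; a higher number here means a weaker inhibitor, a lower number a stronger inhibitor.

Compound 4 `CC/C(=C(/c1ccc(/C=C/C(=O)O)cc1)c1cc2ccccc2[nH]1)c1ccc(C#N)cc1Cl` has not yet been measured. Its relation to compound 3 is cyano in place of chloro on an aromatic carbon. The same kind of change links compound 1 to compound 2, where the difference is cyano in place of chloro on an aromatic carbon, and there it gave a 4.7-fold lower number from compound 1 to compound 2 (0.67 log units; beyond the scatter). The two settings are not identical: in compound 1 the exchanged group stands ortho to a large group, whereas in compound 3 it stands meta to a chloro group and para to a large group. The cores of compound 1 and compound 3 themselves differ by chloro in place of hydrogen on an aromatic carbon, and that step was a 3.8-fold lower number from compound 1 to compound 3 (0.58 log units; beyond the scatter); compound 2 and compound 3 differ by a 1.2-fold higher number from compound 2 to compound 3 (0.09 log units; within the scatter).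

For compound 4 a smaller gain than the earlier one is expected, since compound 3 already gives 11 nM and the cyano step was measured only once; the expected step is a 1.8-fold lower number from compound 3 to compound 4 (0.26 log units; within the scatter). Compound 4 is therefore estimated at 6 nM, most likely between 2.5 nM and 15 nM.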

Compound 4, half-maximal inhibitory concentration: 49 nM
For compound 4 the middle estimate is 8.2-fold (0.91 log units) below the measured one, and the stated range ends below it.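

In this assay, the exchange of chloro for cyano did not carry over from one core to the other, and the two steps run in opposite directions: the same change on two cores in this assay, a 4.7-fold lower number (0.67 log units; beyond the scatter) from compound 1 to compound 2 and a 4.5-fold higher number (0.65 log units; beyond the scatter) from compound 3 to compound 4, 21-fold (1.32 log units) apart, beyond the scatter of two such steps. The new step is a 4.5-fold higher number from compound 3 to compound 4 (0.65 log units; beyond the scatter), and the same result appears as a 5.4-fold higher number from compound 2 to compound 4 (0.74 log units; beyond the scatter), while cyano in place of hydrogen gives a 1.2-fold higher number from compound 1 to compound 4 (0.07 log units; within the scatter). This shows that, in these two pairs, the outcome of the exchange depends on its setting, but it does not show what decides the outcome: the exchange stands at a different place on the ring in each pair, and the core of compound 3 carries a second chloro group, so place and core cannot be separated.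

The compounds shown leave open how a methoxy or trifluoromethyl group would read in place of the chloro group exchanged in compound 3. They also leave open whether a 2,4-dicyanophenyl group would follow either step.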